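Notes on a 4-fluorophenyl replacement in the series

The source may hold more compounds than are shown below. What is called first, only, known or untested is meant among the compounds shown, and "the series" means these compounds.

Among the compounds with values here, compound 2 `COc1cccc(-c2cc(=O)c3cc(OCCCCCCN4CCC(O)CC4)ccc3o2)c1` carries a 3-methoxyphenyl group; in an assay on isolated protein (Cavia porcellus) with Sigma non-opioid intracellular receptor 1 (Homo sapiens) as the target, read by radioligand binding (on this read-out higher numbers stand for weaker inhibition and lower numbers for stronger inhibition), compound 2 gives 111 nM, the lowest of the two numbers measured so far. Compound 1 `O=c1cc(-c2ccccc2)oc2ccc(OCCCCCCN3CCC(O)CC3)cc12` gives 121 nM in this assay, and the step of a 1.1-fold lower number from compound 1 to compound 2 (0.04 log units; within the scatter) is within the scatter, so the two compounds cannot be ordered. Compound 3 `O=c1cc(-c2ccc(F)cc2)oc2ccc(OCCCCCCN3CCC(O)CC3)cc12` is not yet measured; it differs from compound 2 in that (4-fluorophenyl in place of 3-methoxyphenyl on an aromatic carbon). Within the data shown here, no measured step exchanges one aryl group for another. Among the measured compounds shown here, the only measured step, from compound 1 to compound 2, concerns the methoxy group alone and is within the scatter, so its removal is expected to move the number little; the fluorine has no precedent in this set. The expected step for compound 3 in this assay is a 1.1-fold higher number from compound 2 to compound 3 (0.03 log units; within the scatter), none beyond the scatter. Compound 3 is therefore expected to give 120 nM, with a range from 55 nM to 260 nM.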

Compound 3, half-maximal inhibitory concentration: 132 nM
Beside the measured number, compound 3's estimate is 1.1-fold (0.04 log units) below it; the range from low to high includes it.
By their numbers in this assay, from the lowest: compounds 2, 1 and 3 (each within the scatter of the next).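

Within the data shown here, this is the first exchange of one aryl group for another on the aromatic carbon next to the ring oxygen, and it reads as a 1.2-fold higher number from compound 2 to compound 3 (0.08 log units; within the scatter) in this assay. The fluoro group, new to the series, reads as a 1.1-fold higher number from compound 1 to compound 3 (0.04 log units; within the scatter), so phenyl, 3-methoxyphenyl and 4-fluorophenyl all lie within the scatter of one another at this position. No available evidence accounts for this flat reading.

Methoxy and fluoro are shown at different ring positions, so the effect of the group cannot be separated from that of its placement, and neither 3-fluorophenyl nor 4-methoxyphenyl is among the compounds shown. Also open, going by these compounds, is whether an amine or a carboxylic acid on the phenyl ring would give a step beyond the scatter.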